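Methyl in Place of Hydrogen on the Fused Ring

The source may report more compounds than this note shows. Statements on the series, on what has been measured and on what is new or still open speak of the compounds shown alone.

Measured so far in a functional assay on ileum (Cavia porcellus) for antagonist activity at cysteinyl leukotriene receptor (Homo sapiens); on this read-out higher numbers stand for weaker inhibition and lower numbers for stronger inhibition:
Compound 1 `CCC(CC)(CC(=O)Nc1cccc(OCc2ccc3cc(F)ccc3n2)c1)C(=O)O` gives 2 nM.
Compound 2 `CCC(CC)(CC(=O)Nc1cccc(OCc2ccc3ccc(Cl)cc3n2)c1)C(=O)O` gives 0.8 nM.
Compound 3 `CCC(CC)(CC(=O)Nc1cccc(OCc2ccc3ccccc3n2)c1)C(=O)O` gives 0.9 nM.

Compound 3 stands second highest of these three numbers: it sits within the scatter of compound 2, and compound 1 sits well above it. Compound 4 `CCC(CC)(CC(=O)Nc1cccc(OCc2ccc3cc(C)ccc3n2)c1)C(=O)O` is the next one to be measured. It differs from compound 3 in one place: methyl in place of hydrogen on an aromatic carbon.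

Within the data shown here, two measured steps bear on this. The step of a 2.2-fold lower number from compound 1 to compound 3 (0.35 log units; beyond the scatter) shows that a small group at this very position pushes the number up beyond the scatter. The step of a 1.1-fold higher number from compound 2 to compound 3 (0.05 log units; within the scatter) involves a different position and falls within the scatter, so it says little here. A methyl group at this position is therefore expected to move the number at most modestly upward, most likely within the scatter, giving a 1.7-fold higher number from compound 3 to compound 4 (0.22 log units; within the scatter) as the expected step. Compound 4 is thus estimated at 1.5 nM, with a range from 0.5 nM to 4 nM.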

Compound 4, half-maximal inhibitory concentration: 24 nM
Beside the measured number, compound 4's estimate is 16-fold (1.20 log units) below it; measured number above the stated range.
By their numbers in this assay, from the lowest: compounds 2 and 3 (each within the scatter of the next); then compound 1; then compound 4.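

In this assay, this aromatic carbon proves far less tolerant than compound 1 alone suggested: methyl in place of hydrogen gives a 27-fold higher number from compound 3 to compound 4 (1.43 log units; beyond the scatter) and so costs much of the inhibition with a single added carbon. Methyl in place of fluoro on the same carbon gives a 12-fold higher number from compound 1 to compound 4 (1.08 log units; beyond the scatter) as well, so the outcome here depends strongly on which group is present, not just on hydrogen being replaced. No measurement at hand explains why methyl and fluoro differ so much.

As far as these compounds go, it remains open whether an ethyl, a methoxy or an amine on this carbon would behave more like fluoro or more like methyl. Also open, from the compounds shown here alone, is whether methyl on the carbon that carries chloro in compound 2 would bring a similar loss.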